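A Pentyl Chain in Place of the Furan Ring

This account rests on a few compounds, and the source may have more. Where it says the series, first, only, none or still open, it means among the compounds named here.

Compound 3 `COc1cc(-c2cc(C(=O)O)c3ccccc3n2)ccc1OCC(=O)NCc1ccco1` carries a (furan-2-yl)methyl group on its amide-type nitrogen. In an ADME assay on HaCaT cells (Homo sapiens) for inhibition (a higher number here means a weaker inhibitor, a lower number a stronger inhibitor), compound 3 gives only a limit, > 300000 nM. Compound 1 `COc1cc(-c2cc(C(=O)O)c3ccccc3n2)ccc1OCC(=O)Nc1ccc(F)cc1` bears 4-fluorophenyl on the same nitrogen, and in this assay compound 1 gives 286000 nM. Compound 2 `COc1cc(-c2cc(C(=O)O)c3ccccc3n2)ccc1OCC(=O)Nc1ccc(Cl)cc1` bears 4-chlorophenyl there, and in this assay compound 2 likewise reaches only a limit, > 300000 nM. The shared reading is the limit of > 300000 nM in this assay, at which 2 of the 3 values shown sit. Going by the values given here, two measured steps touch the group on this nitrogen: the step of an at least 1.0-fold higher number from compound 1 to compound 3 (0.02 log units; that floor lies within the scatter) and the step that the two limits leave unreadable from compound 2 to compound 3.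

Compound 4 `CCCCCCNC(=O)COc1ccc(-c2cc(C(=O)O)c3ccccc3n2)cc1OC` differs from compound 3 in one place: pentyl in place of furan-2-yl on a saturated chain carbon bound to an amide-type nitrogen. Neither measured step offers a readable size for a change at this position, since compound 3 itself stands at a limit and compound 1 lies close to it. The account therefore expects no change beyond the scatter in this assay and, most likely, once more a limit rather than a number. The expected step is a step that the limit leaves unreadable from compound 3 to compound 4. For compound 4 the estimate in this assay is 350000 nM, with a range from 150000 nM to 800000 nM.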

Compound 4, half-maximal inhibitory concentration: > 300000 nM
Compound 4: no number, only a limit; the forecaster's own chance of this, stated with the estimate: 70%; the middle value lies beyond the limit too.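

With hexyl on the amide-type nitrogen, compound 4 shows that an open saturated chain with no ring also reads in this assay as a limit and not a number, just as the (furan-2-yl)methyl group of compound 3 and the 4-chlorophenyl group of compound 2 do. Going by these compounds alone, the only step that can be read gives a floor and no size, an at least 1.0-fold higher number from compound 1 to compound 4 (0.02 log units; that floor lies within the scatter), and the steps to compound 4 from compound 2 and from compound 3 cannot be read, so the exchange of furan-2-yl for pentyl has no measurable size here. The limit now covers most of the series, and compound 1 alone gives a number: the limit of > 300000 nM in this assay, at which 3 of the 4 values shown sit.

From the compounds shown here alone, whether any group on this nitrogen can bring the reading clearly below that of compound 1 stays open. So does whether a carboxylic acid or an amine at the end of the hexyl chain, or a longer chain, would move the reading in this assay off the limit at all.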